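The compounds below may be only part of what the source reports. "The series", "measured", "known", "first", "only" and "open" are said of these compounds alone.

Compound 1 `C/C(=N/c1ccnc2cc(Cl)ccc12)NCCCCN1CCCCC1` — in an ADME assay (liver, Mus musculus) for metabolic stability, read by LC-MS, using microsomes, tested at 1 uM (a lower number here means that the compound disappears faster, a higher number that the compound lasts longer), compound 1 gives > 1 h, a limit of the assay rather than a number.
Compound 2 `CCN(CC)CCCCN/C(C)=N\c1ccnc2cc(Cl)ccc12` — in this assay compound 2 gives > 1 h, again a limit and not a number.
Compound 3 `C/C(=N/c1ccnc2cc(Cl)ccc12)NCCCN1CCCCC1` — in this assay compound 3 gives 0.417 h.

Compound 3 is therefore the only one of the three with a measured number; the other two sit at the limit (the limit of > 1 h in this assay, at which 2 of the 3 values shown sit). The two steps that lead to compound 3 both run in the same direction: an at least 2.3-fold lower number from compound 1 to compound 3 (0.37 log units; beyond the scatter), and an at least 2.3-fold lower number from compound 2 to compound 3 (0.37 log units; beyond the scatter). The step between compound 1 and compound 2 cannot be read because both values are limits.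

Compound 4 `CCN(CC)CCCCCN/C(C)=N\c1ccnc2cc(Cl)ccc12` has not yet been measured. It differs from compound 3 by 2-(diethylamino)ethyl in place of piperidin-1-yl on a saturated chain carbon, three bonds along the chain from an amine nitrogen. Put another way, compound 4 carries the diethylamino end of compound 2 on a chain one carbon longer, so the measured step from compound 2 to compound 3, read backwards, is the closest guide. Among the measured compounds shown here, since that step and the one from compound 1 were each at least modest and both lowered the number on the way to compound 3, the step of a 2.9-fold higher number from compound 3 to compound 4 (0.46 log units; beyond the scatter) is expected to raise it, most likely back toward the limit. Compound 4 is estimated at 1.2 h, within a range of 0.5 h to 3 h.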

Compound 4, half-life: > 1 h
Compound 4: only a limit was reported; the forecaster's own chance of this, stated with the estimate: 60%; the middle value lies beyond the limit too.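

In this assay, among the compounds shown here, 2-(diethylamino)ethyl in place of piperidin-1-yl on a saturated chain carbon, three bonds along the chain from an amine nitrogen, gives an at least 2.3-fold higher number from compound 3 to compound 4 (0.37 log units; beyond the scatter), which leaves compound 3 as the only one of the four compounds with a number. With the diethylamino end on a chain one carbon longer than in compound 2, compound 4 gives > 1 h, a limit of the assay and not a number, so this longer chain does not bring the half-life down to a readable value. The steps from compound 1 and from compound 2 to compound 4 cannot be read, and neither can any order among these three compounds, because each such pair joins two limits: the limit of > 1 h in this assay, at which 3 of the 4 values shown sit.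

The compounds shown leave open whether the lower number of compound 3 goes with its shorter chain alone, since no diethylamino end appears on that same chain. They also leave open how a pyrrolidine or a morpholine end would behave on either chain length.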